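The source may hold more compounds than are shown below. What is called first, only, known or untested is meant among the compounds shown, and "the series" means these compounds.

Compound 1, with the structure `C[C@@H]1CC[C@@H]2[C@@H](C1)O[C@@H](c1ccccc1)CC2(C)O`, was tested in an ADME assay on MDCK cells (Canis lupus familiaris) for cytotoxicity, read by MTT assay, with a stated time of 48 h (a lower number here means that less compound is tolerated, a higher number that more compound is tolerated), where compound 1 gives 580000 nM. Compound 2, whose structure is `COc1ccc(OC)c([C@H]2CC(C)(O)[C@@H]3CC[C@@H](C)C[C@H]3O2)c1`, gives in this assay 512000 nM, a value that sits within the usual scatter of the number for compound 1. Compound 3, with the structure `C[C@@H]1CC[C@@H]2[C@@H](C1)O[C@@H](c1ccccc1O)CC2(C)O`, reached in this assay only a limit of the assay, > 1080000 nM. Within the data shown here, the one measured step that differs in a single place is the one an at least 1.8-fold higher number from compound 1 to compound 3 (0.26 log units; that floor lies within the scatter); it rests on (the limit of > 1080000 nM in this assay, at which 1 of the 3 values shown sits), so its true size is not known.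

The unmeasured compound 4, whose structure is `C[C@@H]1CC[C@@H]2[C@@H](C1)O[C@@H](c1ccc(O)cc1)CC2(C)O`, differs from compound 1 by the change (hydroxy in place of hydrogen on an aromatic carbon). Among the measured compounds shown here, the step from compound 1 to compound 3 is the only measured precedent for adding a hydroxy to the aromatic ring, and it points upward or to no change, with its floor inside the scatter. On that basis the step from compound 1 to compound 4 is expected to be small and, if anything, upward, so that compound 4 may also end at the limit of this assay, with an expected step of a 1.6-fold higher number from compound 1 to compound 4 (0.19 log units; within the scatter). Compound 4 is therefore estimated at 900000 nM, with a range from 450000 nM to 1500000 nM.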

Compound 4, half-maximal cytotoxic concentration: 127000 nM
For compound 4 the middle estimate is 7.1-fold (0.85 log units) above the measured one; measured number below the stated range.
By their numbers in this assay, from the lowest: compound 4; then compounds 2 and 1 (each within the scatter of the next). At a limit, above all of these: compound 3.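

In this assay, hydroxy in place of hydrogen on an aromatic carbon, para to a large group, gives a 4.6-fold lower number from compound 1 to compound 4 (0.66 log units; beyond the scatter), so at this position the change lowers the tolerated concentration by more than the scatter. The earlier step to compound 3 placed a hydroxy on a different carbon of the same aromatic ring and pointed upward or to no change, so among these compounds the outcome of the change varies with where the hydroxy sits, and adding a hydroxy to this ring has no single outcome. The size of the contrast between compound 3 and compound 4 remains unknown: the limit of > 1080000 nM in this assay, at which 1 of the 4 values shown sits.

Whether the lower number at this position is particular to the hydroxy remains open, since the compounds shown do not reveal what an amine, a carboxylic acid or a longer chain would do at the same place. With a single compound at this position, they also leave open whether the same change would lower the number on another core, and they offer no basis for giving a cause for the step.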